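Trimming the 4-Methoxyphenyl Group from Compound 1

This account rests on a few compounds, and the source may have more. Where it says the series, first, only, none or still open, it means among the compounds named here.

Compound 1 `COc1ccc(-c2ccc3c(c2)oc(=O)n3C(=O)NCCCCc2ccccc2)cc1` gives 67 nM in an assay on HEK293 cells for inhibition of acid ceramidase (Homo sapiens), with a stated time of 10 min; on this read-out lower numbers stand for stronger inhibition and higher numbers for weaker inhibition. Compound 2 `O=C(NCCSCc1ccccc1)n1c(=O)oc2ccccc21` gives 65 nM in this assay, and the two numbers lie within the scatter of each other, so neither stands apart.

Compound 3 `O=C(NCCCCc1ccccc1)n1c(=O)oc2ccccc21` is compound 1 with hydrogen in place of 4-methoxyphenyl on an aromatic carbon. For the measured compounds named here, no measured pair shows this change by itself, yet compound 2, which also lacks the 4-methoxyphenyl, gives 65 nM, so the change is expected to cost little. The step of a 1.5-fold higher number from compound 1 to compound 3 (0.17 log units; within the scatter) is estimated to be small and toward weaker inhibition, if anything. Compound 3 is expected to give 100 nM, within 35 nM to 300 nM.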

Compound 3, half-maximal inhibitory concentration: 64 nM
Compound 3: the middle estimate sits 1.6-fold (0.19 log units) above what was measured, and the stated range covers the measured number.
By their numbers in this assay, from the lowest: compounds 3, 2 and 1 (each within the scatter of the next).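

Hydrogen in place of 4-methoxyphenyl on this aromatic carbon gives a 1.0-fold lower number from compound 1 to compound 3 (0.02 log units; within the scatter) in this assay, the first direct reading of this change. At this position of the shared core, the read-out therefore does not distinguish the 4-methoxyphenyl group from bare hydrogen. Nothing available explains this result.

Only these two substituents are compared here at this position. From the compounds shown here alone, whether an amine or a carboxylic acid on the same aromatic carbon would also leave the number within the scatter remains open.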